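This account rests on a few compounds, and the source may have more. Where it says the series, first, only, none or still open, it means among the compounds named here.

In a functional assay on MCF7 cells (Homo sapiens) for cytotoxicity, read by sulforhodamine B assay, with a stated time of 48 h (a higher number here means a weaker inhibitor, a lower number a stronger inhibitor), compound 1 (`COc1ccc(/C=C/C(=O)c2cccc(-c3cccc(F)c3)c2)cc1O`) is recorded as "not determined" (no result reported) and so offers no comparison, while compound 2 (`COc1ccccc1/C=C/C(=O)c1cccc(-c2cccc(F)c2)c1`) gives 18900 nM as the only figure available, which leaves it unranked. Compound 3 (`COc1ccc(/C=C/C(=O)c2cccc(-c3cccc(F)c3)c2)cc1`) carries 4-methoxyphenyl in place of 2-methoxyphenyl on a double-bonded chain carbon bound to a double-bonded chain carbon, the counted difference being 4-methoxyphenyl in place of 2-methoxyphenyl on a double-bonded chain carbon bound to a double-bonded chain carbon in full. Going by the values given here, no measured step in this assay shows what this change does, so only a small move toward stronger inhibition, not clearly beyond the scatter, is expected. The estimated step is a 1.7-fold lower number from compound 2 to compound 3 (0.24 log units; within the scatter) in size. For compound 3 the expected value is 11000 nM within an estimated range from 4000 nM to 30000 nM overall.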

Compound 3, half-maximal inhibitory concentration: 3080 nM
Beside the measured number, compound 3's estimate is 3.6-fold (0.55 log units) above it; the whole stated range lies above it.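

In this assay, 4-methoxyphenyl in place of 2-methoxyphenyl on a double-bonded chain carbon bound to a double-bonded chain carbon gives a 6.1-fold lower number from compound 2 to compound 3 (0.79 log units; beyond the scatter) in the number. The two compounds have the same atoms and the same counted features, so how these are joined at this position alone separates them. Nothing shown explains the step.

Compound 1 has no number, so steps to it cannot be read. As far as these compounds go, whether 4-aminophenyl in place of 4-methoxyphenyl would keep this stronger inhibition remains open.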